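This account rests on a few compounds, and the source may have more. Where it says the series, first, only, none or still open, it means among the compounds named here.

Measured so far in a functional assay on L02 cells (Homo sapiens) for inhibition, read by MTT assay, with a stated time of 72 h; on this read-out lower numbers stand for stronger inhibition and higher numbers for weaker inhibition:

compound 1, `C=C(c1ccc(F)c(F)c1)C1COC2(CCCC2)OO1`, 8840 nM
compound 2, `C=C(c1ccc(Cl)c(Cl)c1Cl)C1COC2(CCCCC2)OO1`, 1220 nM

Compound 1 carries the highest of the two numbers in this assay; compound 2 sits clearly lower, so compound 1 is the weaker inhibitor of the pair.

Compound 3, `C=C(c1ccc(OC)c(F)c1)C1COC2(CCCC2)OO1`, differs from compound 1 by one change: methoxy in place of fluoro on an aromatic carbon. Going by the values given here, no measured pair shows this change, so its effect is unknown. The expectation for this assay is a step of no size beyond the scatter, in no fixed direction. Compound 3 is therefore estimated at 9000 nM, range 3000 nM to 27000 nM, which means an expected step of a 1.0-fold higher number from compound 1 to compound 3 (0.01 log units; within the scatter).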

Compound 3, half-maximal inhibitory concentration: 18500 nM
Estimate against measurement, compound 3: 2.1-fold (0.31 log units) below; the measured number falls inside the stated range.
By their numbers in this assay, from the lowest: compound 2; then compound 1; then compound 3.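

In this assay, going by these compounds alone, methoxy in place of fluoro on this aromatic carbon gives a 2.1-fold higher number from compound 1 to compound 3 (0.32 log units; beyond the scatter), the first single-change step. The position, ortho to a fluoro group and para to a large group, therefore responds to this change, with weaker inhibition in this one pair. Within the data shown here, nothing measured so far accounts for the step.

As far as these compounds go, whether an amine or a longer chain such as ethoxy at this position would move the number further remains open. So does whether the same change acts alike on the core of compound 2.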